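Dichlorophenyl ether series: from compound 2 to compound 4

The compounds below may be only part of what the source reports. "The series", "measured", "known", "first", "only" and "open" are said of these compounds alone.

Measured in a functional assay on MDA-MB-231 cells (Homo sapiens) for antiproliferative activity, read by MTT assay, with a stated time of 72 h; on this read-out lower numbers stand for stronger inhibition and higher numbers for weaker inhibition:
- compound 1 `NC1=NC2(CCSCC2)N(OCCCOc2ccc(Cl)c(Cl)c2)C(N)=N1`: 10 nM
- compound 2 `NC1=NC2(CCOCC2)N(OCCCOc2ccccc2)C(N)=N1`: "not determined" (no result reported)
- compound 3 `NC1=NC2(CCSCC2)N(OCCCOc2cccc(Cl)c2Cl)C(N)=N1`: 1 nM

Compound 2 has no number to stand on, since in this assay compound 2 is entered as "not determined" (no result reported). Compound 4 `NC1=NC2(CCOCC2)N(OCCCOc2ccc(Cl)c(Cl)c2)C(N)=N1` departs from it by 3,4-dichlorophenyl in place of phenyl on an oxygen on a saturated carbon. Going by the values given here, the only measured step at this place is a 10-fold lower number from compound 1 to compound 3 (1.00 log units; beyond the scatter), which lies beyond the scatter. That step exchanges one dichlorophenyl pattern for another and does not remove the chlorines, so it does not size the change from phenyl. With no number for compound 2, no size or direction of step can be expected in this assay. The estimate therefore leans on a single value: compound 1 carries the same 3,4-dichlorophenyl on a different core and gives 10 nM. The core difference is unmeasured, so the range is kept wide. For compound 4 the expected value is 15 nM, with an estimated range of 3 nM to 80 nM.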

Compound 4, half-maximal inhibitory concentration: 590 nM
Compound 4: the middle estimate sits 39-fold (1.59 log units) below what was measured, outside the stated range (above it).
By their numbers in this assay, from the lowest: compound 3; then compound 1; then compound 4.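

In this assay, going by these compounds alone, compound 2 has no number, so no step from it to compound 4 can be read. The compounds shown leave open the size and direction of 3,4-dichlorophenyl in place of phenyl on the core of compound 4. No evidence bears on this result.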